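The source may report more compounds than this note shows. Statements on the series, on what has been measured and on what is new or still open speak of the compounds shown alone.

Measured so far:
compound 1 `Fc1ccc2nc(-c3ccnnc3)n(C3CC3)c2c1`: > 10000 nM
compound 2 `Fc1cc2nc(-c3cncnc3)n(C3CC3)c2cc1F`: 2270 nM

In an ADME assay on cells for inhibition of cytochrome P450 11B1, mitochondrial (Homo sapiens), read by HPLC, with a stated time of 60 min (a higher number here means a weaker inhibitor, a lower number a stronger inhibitor), compound 1 gives > 10000 nM, which is a limit of the assay and not a number. In this assay, within the data shown here, compound 2 gives 2270 nM, the only number in the set. The other value shown, that of compound 1, is a limit (the limit of > 10000 nM in this assay, at which 1 of the 2 values shown sits). Compound 2 therefore cannot be ranked against anything measured. Among the measured compounds shown here, no step between two measured compounds is available to calibrate the change toward compound 3 `Fc1cc2nc(-c3cncnc3C(F)F)n(C3CC3)c2cc1F`, which is still to be measured. The change is difluoromethyl in place of hydrogen on an aromatic carbon, next to the ring nitrogen and ortho to a large group. With nothing measured to set its size, the expected step in this assay is small, possibly toward a stronger inhibitor, and not clearly beyond the scatter. Compound 3 is expected at 1500 nM, in a range from 400 nM to 6000 nM. The estimated step is a 1.5-fold lower number from compound 2 to compound 3 (0.18 log units; within the scatter).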

Compound 3, half-maximal inhibitory concentration: 4330 nM
Compound 3: the middle estimate sits 2.9-fold (0.46 log units) below what was measured; measured number inside the range.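

In this assay, among these compounds, difluoromethyl in place of hydrogen on an aromatic carbon, next to the ring nitrogen and ortho to a large group, gives a 1.9-fold higher number from compound 2 to compound 3 (0.28 log units; within the scatter) and so provides the first readable step at this position. A group of 3 heavy atoms on this carbon therefore leaves the number within the usual scatter, and compound 3 still reads as a number, not as a limit. Nothing shown bears on why the step has this size.

On these data alone, whether this tolerance extends to other groups on the same carbon stays open, as a single step cannot say how a methyl, a methoxy or an amine would read there. Whether any group at this position would give a lower number is equally unresolved.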